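Ethyl on the Urea Nitrogen of a Cytotoxicity Series

The source may hold more compounds than are shown below. What is called first, only, known or untested is meant among the compounds shown, and "the series" means these compounds.

Compound 1, `NC(=O)N1CCN(C(=S)SCc2cn(Cc3ccccc3F)nn2)CC1`: in a functional assay on SMMC-7721 cells (Homo sapiens) for cytotoxicity, read by MTT assay, with a stated time of 72 h (a higher number here means a weaker inhibitor, a lower number a stronger inhibitor), compound 1 gives > 128000 nM, which is a limit of the assay.
Compound 2, `CCNC(=O)N1CCN(C(=S)SCc2cn(Cc3ccccc3F)nn2)CC1`: in this assay compound 2 gives > 128000 nM, again a limit.
Compound 3, `Cc1ccc(Cn2cc(CSC(=S)N3CCN(C(N)=O)CC3)nn2)cc1`: in this assay compound 3 gives > 128000 nM, also a limit.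

All three measured compounds sit at the same limit, as the limit of > 128000 nM in this assay, at which 3 of the 3 values shown sit, records. The change from compound 1 to compound 2 is ethyl in place of hydrogen on an amide-type nitrogen, and its step, a step that the two limits leave unreadable from compound 1 to compound 2, cannot be read because both values are limits. The two cores differ by 4-methylphenyl in place of 2-fluorophenyl on a saturated chain carbon bound to an aromatic nitrogen, and the step that the two limits leave unreadable from compound 1 to compound 3 is likewise unreadable for the same reason.

Compound 4, `CCNC(=O)N1CCN(C(=S)SCc2cn(Cc3ccc(C)cc3)nn2)CC1`, is not yet measured in this assay. It arises from compound 3 by ethyl in place of hydrogen on an amide-type nitrogen. The place of this change is the same, word for word, as in the change from compound 1 to compound 2, so this is the same change on a core that differs only in the benzyl part. That change gave no readable step from compound 1 to compound 2, and compound 3 itself sits at the limit, so the expected step from compound 3 to compound 4 is a step that the limit leaves unreadable from compound 3 to compound 4. On that basis compound 4 is estimated at 200000 nM, with a range from 100000 nM to 600000 nM, and most likely the assay will again report only a limit.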

Compound 4, half-maximal inhibitory concentration: > 128000 nM
Compound 4: only a limit was reported; the forecaster's own chance of this, stated with the estimate: 85%; the middle value is on the limit's open side.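

Compound 4 gives > 128000 nM in this assay, and this value is a limit. Neither the step from compound 3 to compound 4 nor the step from compound 2 to compound 4 can be read, as each joins two limits. The compounds shown leave open whether ethyl in place of hydrogen, or 4-methylphenyl in place of 2-fluorophenyl, changes the strength of these compounds at all, with every value resting at one point: the limit of > 128000 nM in this assay, at which 4 of the 4 values shown sit.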